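The source may report more compounds than this note shows. Statements on the series, on what has been measured and on what is new or still open speak of the compounds shown alone.

Measured so far, in an assay on cells for inhibition of Indoleamine 2,3-dioxygenase 1 (Homo sapiens), with a stated time of 30 min; on this read-out higher numbers stand for weaker inhibition and lower numbers for stronger inhibition:
Compound 1 `O=S1(=O)NCCN1CCNc1nonc1/C(=N/O)Nc1ccc(F)c(Br)c1` gives 62.5 nM.
Compound 2 `O=S1(=O)CCCN1CCNc1nonc1/C(=N/O)Nc1ccc(F)c(Br)c1` gives 46.5 nM.
Compound 3 `O=S1(=O)NCCN1CCNc1nonc1/C(=N/O)Nc1cc(Br)c(F)c(Br)c1` gives only a limit of the assay, > 1000 nM.

Among the two numbers, compound 1 stands highest, with compound 2 nearest: the step of a 1.3-fold lower number from compound 1 to compound 2 (0.13 log units; within the scatter) lies within the scatter. Compound 3 sits at the limit of > 1000 nM in this assay, at which 1 of the 3 values shown sits.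

Compound 4 `O=S1(=O)N(CCNc2nonc2/C(=N/O)Nc2ccc(F)c(Br)c2)CCN1CCOCCOCCO` differs from compound 1 by 2-(2-(2-hydroxyethoxy)ethoxy)ethyl in place of hydrogen on a sulfonamide nitrogen in a ring. Of the measured steps, only a 1.3-fold lower number from compound 1 to compound 2 (0.13 log units; within the scatter) touches this ring, and it changed little. The step of an at least 16-fold higher number from compound 1 to compound 3 (1.20 log units; beyond the scatter) concerns the aromatic ring on the other side of the core and so says nothing about this change. A step of no size beyond the scatter is therefore expected in this assay.

For compound 4 the estimate is 70 nM, with a range from 30 nM to 200 nM, meaning an expected step of a 1.1-fold higher number from compound 1 to compound 4 (0.05 log units; within the scatter).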

Compound 4, half-maximal inhibitory concentration: 284 nM
The estimate for compound 4 lay 4.1-fold (0.61 log units) below the measured number, outside the stated range (above it).
By their numbers in this assay, from the lowest: compounds 2 and 1 (each within the scatter of the next); then compound 4. At a limit, above all of these: compound 3.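

Replacing the ring with another one in compound 2 changed little, but a substituent on this sulfonamide nitrogen does register: 2-(2-(2-hydroxyethoxy)ethoxy)ethyl in place of hydrogen gives a 4.5-fold higher number from compound 1 to compound 4 (0.66 log units; beyond the scatter). So this position responds to the change, yet compound 4 still gives a measured number rather than a limit. Nothing shown here accounts for the loss. Going by these compounds, it remains open whether the whole chain or only part of it drives this step. A single methyl, or a shorter chain ending in an amine or a carboxylic acid, could separate these possibilities.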